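Exchanging one aryl group: compound 2 to compound 3

The source may report more compounds than this note shows. Statements on the series, on what has been measured and on what is new or still open speak of the compounds shown alone.

Measured in a functional assay on DLD-1 cells (Homo sapiens) for antiproliferative activity, read by CellTiter-Glo, with a stated time of 72 h; on this read-out higher numbers stand for weaker inhibition and lower numbers for stronger inhibition:
- compound 1 `CC1CCN(C2CCN(S(=O)(=O)c3cccc(N)c3)CC2)CC1`: 3400 nM
- compound 2 `CC1CCN(C2CCN(S(=O)(=O)c3cccc(-c4ccc(F)cc4)c3)CC2)CC1`: 12 nM

Compound 2 holds the lower of the two numbers, and its gap to compound 1 is beyond the scatter. The next compound, compound 3 `Cc1cc(C)cc(-c2cccc(S(=O)(=O)N3CCC(N4CCC(C)CC4)CC3)c2)c1`, carries 3,5-dimethylphenyl in place of 4-fluorophenyl on an aromatic carbon.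

Going by the values given here, one measured step bears on this change: a 280-fold lower number from compound 1 to compound 2 (2.45 log units; beyond the scatter). That large step replaced amino with 4-fluorophenyl, so it shows how much the group at this carbon can matter. Among the compounds with values here, it does not compare two aromatic groups, and no measured pair does. A small step in this assay is therefore expected, perhaps none beyond the scatter, with a slight lean towards a higher number.

For compound 3 the expected value is 20 nM, within an estimated range of 6 nM to 70 nM. This estimate means a 1.7-fold higher number from compound 2 to compound 3 (0.22 log units; within the scatter).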

Compound 3, half-maximal inhibitory concentration: 41 nM
Beside the measured number, compound 3's estimate is 2.1-fold (0.31 log units) below it; the measured number falls inside the stated range.
By their numbers in this assay, from the lowest: compound 2; then compound 3; then compound 1.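

In this assay, going by these compounds alone, the first comparison of two aromatic groups at this carbon gives a 3.4-fold higher number from compound 2 to compound 3 (0.53 log units; beyond the scatter) and shows that the choice of aromatic group still counts once one is present. Against amino, 3,5-dimethylphenyl gives an 83-fold lower number from compound 1 to compound 3 (1.92 log units; beyond the scatter) and so keeps most of the drop seen with 4-fluorophenyl, which means this second aromatic group also stands far from the amino compound. Nothing measured here explains the difference between the two aromatic groups.

The shown compounds remove the fluorine and add two methyl groups in one exchange, so the share of each in the higher number of compound 3 stays open. Whether a plain phenyl, a 4-methylphenyl or a pyridyl ring at this carbon would sit closer to compound 2 or to compound 3 is also unknown.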